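This account rests on a few compounds, and the source may have more. Where it says the series, first, only, none or still open, it means among the compounds named here.

Measured compounds: compound 1 `O=C1NC(=O)C(Cc2ccc(Oc3ncc(C(F)(F)F)cc3Cl)cc2Cl)S1` gives 26 nM in a functional assay for agonist activity at Free fatty acid receptor 1 (Homo sapiens), read by FLIPR, in the presence of a further agent that is not named here; on this read-out lower numbers stand for an effect already at smaller amounts and higher numbers for an effect only at larger amounts of compound; compound 2 `O=C1NC(=O)C(Cc2ccc(Oc3cccc4ccccc34)cc2)S1` gives 135 nM; compound 3 `O=C1NC(=O)C(Cc2ccc(Oc3ncc(Cl)cc3Cl)cc2Cl)S1` gives 63 nM.

Compound 1 stands at the lowest number of the three, with compound 3 nearest and compound 2 furthest. Among the measured compounds shown here, the one step measured in one place, a 2.4-fold higher number from compound 1 to compound 3 (0.38 log units; beyond the scatter), was modest and concerned the other aromatic ring. Compound 4 `COc1cc(Oc2ncc(C(F)(F)F)cc2Cl)ccc1CC1SC(=O)NC1=O` differs from compound 1 in another way: methoxy in place of chloro on an aromatic carbon, that is, on the ring of carbon only, ortho to a (2,4-dioxo-1,3-thiazolidin-5-yl)methyl group and meta to a large group. For the measured compounds named here, no measured pair shows this change, and compound 2 differs from compound 1 in more than one place, so its value gives no direct guide. With the only shown step being modest, the change in compound 4 is expected to produce at most a small step, in either direction. For compound 4 the estimate is 40 nM, within 12 nM to 130 nM, which is expected to mean a 1.5-fold higher number from compound 1 to compound 4 (0.19 log units; within the scatter).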

Compound 4, half-maximal effective concentration: 13900 nM
Estimate against measurement, compound 4: 350-fold (2.54 log units) below; the whole stated range lies below it.
By their numbers in this assay, from the lowest: compound 1; then compound 3; then compound 2; then compound 4.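

In this assay, among the compounds shown here, the place ortho to a (2,4-dioxo-1,3-thiazolidin-5-yl)methyl group responds far more strongly to a single change than the earlier data could show: methoxy in place of chloro gives a 530-fold higher number from compound 1 to compound 4 (2.73 log units; beyond the scatter), whereas the only earlier step, a 2.4-fold higher number from compound 1 to compound 3 (0.38 log units; beyond the scatter), was modest and lay on the other aromatic ring. A swap of one small group for another on the ring of carbon only can therefore move the number much further than that earlier change did. Nothing measured here accounts for the size of this step.

Going by these compounds, only chloro and methoxy are compared at this place, so it remains open whether the large step is particular to methoxy or would follow from replacing chloro with other groups. A fluoro, methyl or hydroxy group at the same place could help to separate these two readings.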